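A few compounds are considered here, and "the series" means these few. Any claim that something is new, unique, unknown or untested is made for them only; others in the source may bear on it.

Compound 1 `CC(=O)OC[C@H]1O[C@H](OC[C@@H](Cn2cc(CN(c3nc(-c4cccc(C)c4)no3)C3CCCCC3)nn2)OC(C)=O)C=C[C@@H]1OC(C)=O`: 46.4 ug/mL
Compound 2 `CC(=O)OC[C@H]1O[C@H](OC[C@@H](Cn2cc(CN(c3nc(-c4ccc(Br)cc4)no3)C3CCCCC3)nn2)OC(C)=O)C=C[C@@H]1OC(C)=O`: 39.1 ug/mL
Compound 3 `C#CCN(c1nc(-c2cccc(C)c2)no1)C1CCCCC1`: 25.9 ug/mL

All three were tested in an ADME assay on RAW264.7 cells (Mus musculus) for cytotoxicity, read by MTT assay, with a stated time of 48 h; on this read-out higher numbers stand for lower toxicity in this test and lower numbers for higher toxicity in this test. Compound 1 and compound 2 share one core and differ by a single change, (4-bromophenyl in place of 3-methylphenyl on an aromatic carbon); this change gives a 1.2-fold lower number from compound 1 to compound 2 (0.07 log units; within the scatter). Compound 3 rests on a different core, and the difference between the two cores is not broken down here. Compound 4 `C#CCN(c1nc(-c2ccc(Br)cc2)no1)C1CCCCC1` has not yet been measured in this assay. It arises from compound 3 by the same change, (4-bromophenyl in place of 3-methylphenyl on an aromatic carbon), at the same place on the five-membered ring. Because the earlier step of a 1.2-fold lower number from compound 1 to compound 2 (0.07 log units; within the scatter) stays within the scatter, a step of similar size is expected here, a 1.2-fold lower number from compound 3 to compound 4 (0.07 log units; within the scatter). On that basis compound 4 is estimated at 22 ug/mL, with a likely range from 12 ug/mL to 40 ug/mL.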

Compound 4, half-maximal cytotoxic concentration: 15.7 ug/mL
Compound 4: middle estimate off by 1.4-fold (0.15 log units), on the high side, and the stated range covers the measured number.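

In this assay, putting 4-bromophenyl in place of 3-methylphenyl on the second core gives a 1.6-fold lower number from compound 3 to compound 4 (0.22 log units; within the scatter). Set beside the earlier step, the change looks the same on both cores, with no difference that can be told from ordinary assay noise: the same change on two cores in this assay, a 1.2-fold lower number (0.07 log units; within the scatter) from compound 1 to compound 2 and a 1.6-fold lower number (0.22 log units; within the scatter) from compound 3 to compound 4, 1.4-fold (0.14 log units) apart, within the scatter of two such steps This does not show that the change truly alters the number on either core, and two pairs cannot establish a rule for any further core in this series.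

Going by these compounds, what an amine or a carboxylic acid would do in place of these two aromatic groups remains open. So does the outcome of this same change on a third core.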